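The source may hold more compounds than are shown below. What is called first, only, known or untested is meant among the compounds shown, and "the series" means these compounds.

Three compounds share one core and differ only in the group carried on the five-membered aromatic ring. Compound 1 `CCCCCCCCCCc1ccc(-c2noc(CCCN(C)C)n2)cc1` bears 3-(dimethylamino)propyl and in an assay on HeLa cells for inhibition of sphingosine-1-phosphate transporter SPNS2 (Mus musculus), read by LC-MS, tested at 2 uM (on this read-out higher numbers stand for more inhibition at the one concentration tested (going by the name of the read-out) and lower numbers for less inhibition), compound 1 gives 8%. Compound 2 `CCCCCCCCCCc1ccc(-c2noc(C3CCNCC3)n2)cc1` carries piperidin-4-yl, and in this assay compound 2 gives 66%. Compound 3 `CCCCCCCCCCc1ccc(-c2noc([C@@H]3CC[C@H](N)C3)n2)cc1` carries 3-aminocyclopentyl, and in this assay compound 3 gives 38%, the second highest of the three numbers: compound 2 lies above it by a number 28 percentage points lower from compound 2 to compound 3 (beyond the scatter), and compound 1 below it by a number 30 percentage points higher from compound 1 to compound 3 (beyond the scatter).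

Compound 4 `CCCCCCCCCCc1ccc(-c2noc([C@@H](N)CCN)n2)cc1` is the next step from compound 3. The change is 1,3-diaminopropyl in place of 3-aminocyclopentyl on an aromatic carbon.

Going by the values given here, two measured steps bear on it. The gain from compound 1 to compound 3, a number 30 percentage points higher from compound 1 to compound 3 (beyond the scatter), came when a chain gave way to a ring; compound 4 goes the other way, back to a chain. The step of a number 28 percentage points lower from compound 2 to compound 3 (beyond the scatter) shows that rings differ among themselves as well. Among the compounds with values here, no measured pair has the 1,3-diaminopropyl group, so its weight is unknown. Compound 4 is therefore expected to fall somewhat, by a number 10 percentage points lower from compound 3 to compound 4 (within the scatter), with a wide range. The estimate for compound 4 is 28%, expected to lie between 8% and 55%.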

Compound 4, a percentage reported as inhibition, at one concentration (the size of the read-out at that concentration, not a potency): 14%
Compound 4: the middle estimate sits 14 percentage points above what was measured; the range from low to high includes it.
By their numbers in this assay, from the lowest: compounds 1 and 4 (each within the scatter of the next); then compound 3; then compound 2.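

Opening the ring into a chain does not hold the level at this position: in this assay the change to 1,3-diaminopropyl is a step of a number 24 percentage points lower from compound 3 to compound 4 (beyond the scatter) and the gap to the piperidin-4-yl group grows to a number 52 percentage points lower from compound 2 to compound 4 (beyond the scatter) as well. Against 3-(dimethylamino)propyl, the new chain gives a number 6 percentage points higher from compound 1 to compound 4 (within the scatter) so the two chains cannot be told apart despite the second nitrogen of 1,3-diaminopropyl, and among these four compounds both ring-bearing groups read above both chains, with no compound going against that. Nothing measured here accounts for this split between rings and chains.

The compounds shown leave open whether the ring itself or the place of its nitrogen matters more, since a piperidin-3-yl or a pyrrolidin-3-yl group could side with either piperidin-4-yl or 3-aminocyclopentyl. They also leave open whether a chain with a single primary amine, such as 3-aminopropyl, would read with the two chains here or closer to the rings.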